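The source may report more compounds than this note shows. Statements on the series, on what has been measured and on what is new or still open speak of the compounds shown alone.

Among the compounds with values here, compound 2 `Fc1ccccc1-c1cc(COc2ccccc2-c2nc3ccccc3s2)on1` gives 22500 nM in a functional assay on A549 cells (Homo sapiens) for cytotoxicity, read by MTT assay, with a stated time of 24 h (on this read-out lower numbers stand for stronger inhibition and higher numbers for weaker inhibition), the highest of the two numbers measured so far. Compound 1 `Brc1ccc(-c2cc(COc3ccccc3-c3nc4ccccc4s3)on2)cc1` gives 19200 nM, and the change between them, a 1.2-fold higher number from compound 1 to compound 2 (0.07 log units; within the scatter), stays within the scatter. Compound 3 `COc1ccc(-c2cc(COc3ccccc3-c3nc4ccccc4s3)on2)cc1` is the next compound, differing from compound 2 by 4-methoxyphenyl in place of 2-fluorophenyl on an aromatic carbon. Within the data shown here, the only step that bears on this position is the one from compound 1 to compound 2, which was within the scatter, so no step beyond the scatter is expected here, in either direction. Compound 3 is therefore estimated at 21000 nM, within a range from 9000 nM to 50000 nM, which means an expected step of a 1.1-fold lower number from compound 2 to compound 3 (0.03 log units; within the scatter).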

Compound 3, half-maximal inhibitory concentration: 24100 nM
For compound 3 the middle estimate is 1.1-fold (0.06 log units) below the measured one, within the range that was stated.
By their numbers in this assay, from the lowest: compounds 1, 2 and 3 (each within the scatter of the next).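

In this assay, the step with 4-methoxyphenyl in place of 2-fluorophenyl is a 1.1-fold higher number from compound 2 to compound 3 (0.03 log units; within the scatter), and methoxy in place of bromo gives a 1.3-fold higher number from compound 1 to compound 3 (0.10 log units; within the scatter). A phenyl ring on this carbon of the five-membered ring can thus carry an oxygen-containing group, with its hydrogen-bond acceptor, and the number still stays within the scatter of the bromo and fluoro compounds. No measurement is at hand that would explain this. Still open, going by these compounds, is whether an amine or a carboxylic acid on that phenyl ring, or a longer chain in its place, would produce a step beyond the scatter.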